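A few compounds are considered here, and "the series" means these few. Any claim that something is new, unique, unknown or untested is made for them only; others in the source may bear on it.

Measured compounds in a functional assay on BGC-823 cells (Homo sapiens) for antiproliferative activity, read by MTT assay, with a stated time of 48 h; a higher number here means a weaker inhibitor, a lower number a stronger inhibitor:
- compound 1, `S=c1oc(-c2ccc3c(c2)OCCO3)nn1CN1CCN(c2cccc(Cl)c2)CC1`: compound 1 gives > 50000 nM, a limit.
- compound 2, `COc1ccc(N2CCN(Cn3nc(-c4ccc5c(c4)OCCO5)oc3=S)CC2)cc1`: compound 2 gives 18900 nM.

For the measured compounds named here, compound 2 holds the only number in this assay. The value of compound 1 is a limit, (the limit of > 50000 nM in this assay, at which 1 of the 2 values shown sits). Compound 3, `O=[N+]([O-])c1ccc(N2CCN(Cn3nc(-c4ccc5c(c4)OCCO5)oc3=S)CC2)cc1`, differs from compound 2 by nitro in place of methoxy on an aromatic carbon. Going by the values given here, the single measured step, an at least 2.6-fold lower number from compound 1 to compound 2 (0.42 log units; beyond the scatter), alters the same phenyl but exchanges a different substituent, so it does not bear directly on this change. No step beyond the scatter is expected, a 1.2-fold lower number from compound 2 to compound 3 (0.07 log units; within the scatter). Compound 3 is estimated at 16000 nM, expected between 5000 nM and 50000 nM.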

Compound 3, half-maximal inhibitory concentration: > 50000 nM
Compound 3 was reported as a limit; the forecaster's own chance of this, stated with the estimate: 25%; middle value at least 3.1-fold (0.49 log units) away from the limit.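

In this assay, nitro in place of methoxy on this aromatic carbon, para to a large group, gives an at least 2.6-fold higher number from compound 2 to compound 3 (0.42 log units; beyond the scatter), so the group at this position does change the read-out, and methoxy is the only substituent shown here that gives a number. The value of compound 3 is a limit, as is that of compound 1: the limit of > 50000 nM in this assay, at which 2 of the 3 values shown sit. The step from compound 1 to compound 3 cannot be read.

Still open, as far as these compounds go, is how an amine, a hydroxyl or a fluorine on this same carbon would read. From the compounds shown here alone, the full size of the step to compound 3 also remains open.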